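Swapping Isopropyl for Cyclohexyl in a Peptide-like Series

The source may hold more compounds than are shown below. What is called first, only, known or untested is meant among the compounds shown, and "the series" means these compounds.

Compound 1 `CC(C)[C@H](NC(=O)c1ccc(Br)cc1)C(=O)N1CCC[C@H]1C(=O)N[C@@H](CCCNC(=N)N)C(=O)CF` is a short peptide-like molecule with an isopropyl group on a saturated chain carbon bound to an amide-type nitrogen and a carbonyl carbon. In a functional assay on OCI-Ly3 cells (Homo sapiens) for inhibition, read by CellTiter-Glo, with stated times of 48 h and 96 h (a higher number here means a weaker inhibitor of growth, a lower number a stronger inhibitor of growth), compound 1 gives 130 nM. Compound 3 `N=C(N)NCCC[C@H](NC(=O)[C@@H]1CCCN1C(=O)[C@@H](NC(=O)c1ccc(Br)cc1)C1CCCCC1)C(=O)CF` keeps everything else and carries cyclohexyl in place of isopropyl on a saturated chain carbon bound to an amide-type nitrogen and a carbonyl carbon. In this assay compound 3 gives 130 nM. The measured step from this single change is no change at the digits printed from compound 1 to compound 3 (within the scatter), so the two compounds cannot be told apart in this assay.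

Compound 2 `CC(C)[C@H](NC(=O)c1ccc(Br)cc1)C(=O)N[C@@H](CO)C(=O)N[C@@H](CCCNC(=N)N)C(=O)CF` is built on a different core; how the core of compound 2 differs from the core of compound 1 is not broken down here. In this assay compound 2 gives 150 nM, and the values of compound 1 and compound 2 lie within the scatter of each other.

Compound 4 `N=C(N)NCCC[C@H](NC(=O)[C@H](CO)NC(=O)[C@@H](NC(=O)c1ccc(Br)cc1)C1CCCCC1)C(=O)CF` has not yet been measured. It stands to compound 2 as compound 3 stands to compound 1: it carries cyclohexyl in place of isopropyl on a saturated chain carbon bound to an amide-type nitrogen and a carbonyl carbon, and the place of the change is the same in both pairs, so this is the same change made on the core of compound 2.

The expectation for compound 4 rests on one measured example. Because no change at the digits printed from compound 1 to compound 3 (within the scatter) was the result of this change on the core of compound 1, the step from compound 2 to compound 4 is estimated to be no change at the digits printed from compound 2 to compound 4 (within the scatter). Compound 4 is therefore expected to give about 150 nM in this assay, with a likely range from 75 nM to 300 nM. Whether the second core responds in the same way is what the coming measurement will show.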

Compound 4, concentration for 50% growth inhibition: 240 nM
Compound 4: middle estimate off by 1.6-fold (0.20 log units), on the low side, and the stated range covers the measured number.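

In this assay, putting cyclohexyl in place of isopropyl on the core of compound 2 gives a 1.6-fold higher number from compound 2 to compound 4 (0.20 log units; within the scatter), so this assay does not separate the two compounds, even though the printed numbers differ. Set beside the earlier result, the change reads the same on both cores as far as this measurement can tell: the same change on two cores in this assay, no change at the digits printed (within the scatter) from compound 1 to compound 3 and a 1.6-fold higher number (0.20 log units; within the scatter) from compound 2 to compound 4, 1.6-fold (0.20 log units) apart, within the scatter of two such steps. For the compounds shown here, this supports carrying the swap from the core of compound 1 to the core of compound 2 in this assay, but it rests on only two pairs of compounds, it cannot exclude a small real difference hidden in the scatter, and it says nothing about any other core or any other kind of measurement.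

The compounds shown leave open how other groups would behave on the same saturated chain carbon bound to an amide-type nitrogen and a carbonyl carbon, such as a phenyl ring, or a chain ending in an amine or a carboxylic acid, since isopropyl and cyclohexyl are the only two groups compared there. They also leave open whether a larger group at that place would still leave the number in this assay within the scatter.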